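The source may hold more compounds than are shown below. What is called first, only, known or untested is meant among the compounds shown, and "the series" means these compounds.

Compound 1 `O=C(O)CCC/C=C\C[C@H]1[C@@H]2CCC(C2)[C@@H]1NS(=O)(=O)c1ccc([N+](=O)[O-])cc1` gives 1400 nM in a functional assay (plasma) for inhibition, with Oryctolagus cuniculus as the target; a higher number here means a weaker inhibitor, a lower number a stronger inhibitor. Compound 2 `O=C(O)CCC/C=C\C[C@H]1[C@@H]2CCC(C2)[C@@H]1NS(=O)(=O)c1ccccc1` gives 1000 nM; 7400 nM; 600 nM (3 entries). Compound 3 `O=C(O)CCC/C=C\C[C@H]1[C@@H]2CCC(C2)[C@@H]1NS(=O)(=O)CCCc1ccccc1` gives 14000 nM.

Compound 3 stands highest of the two single numbers in this assay; the nearest, compound 1, lies below it by a 10-fold higher number from compound 1 to compound 3 (1.00 log units; beyond the scatter). Compound 2 gives no single number; its entries spread widely, as the several entries of compound 2 in this assay, 1000 nM; 7400 nM; 600 nM (3 entries) shows.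

Compound 4 `O=C(O)CCC/C=C\C[C@H]1[C@@H]2CCC(C2)[C@@H]1NS(=O)(=O)Cc1ccccc1` differs from compound 3 by phenyl in place of phenethyl on a saturated chain carbon bound to a sulfonyl sulfur. Among the compounds with values here, no measured step shortens this chain directly. Within the data shown here, the one step that bears on the group on the sulfonyl sulfur is a 10-fold higher number from compound 1 to compound 3 (1.00 log units; beyond the scatter), which takes an aryl set directly on the sulfur to the longer 3-phenylpropyl and raises the number. Benzyl sits between those two, so compound 4 is expected to give a somewhat lower number than compound 3, a step of a 2.8-fold lower number from compound 3 to compound 4 (0.45 log units; beyond the scatter). Compound 4 is estimated at 5000 nM, within 1500 nM to 15000 nM.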

Compound 4, half-maximal inhibitory concentration: 113000 nM
Compound 4: the middle estimate sits 23-fold (1.35 log units) below what was measured, outside the stated range (above it).
By their numbers in this assay, from the lowest: compound 1; then compound 3; then compound 4.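

In this assay, the group on the sulfonyl sulfur does not follow chain length: shortening 3-phenylpropyl to benzyl raises the number, with an 8.1-fold higher number from compound 3 to compound 4 (0.91 log units; beyond the scatter). Benzyl therefore stands above both neighbours rather than in the middle, and the gap to the 4-nitrophenyl group is larger still, with an 81-fold higher number from compound 1 to compound 4 (1.91 log units; beyond the scatter). Compound 2, the unsubstituted phenyl, gives no single number to place in this order: the several entries of compound 2 in this assay, 1000 nM; 7400 nM; 600 nM (3 entries)

As far as these compounds go, it remains open where a 2-phenylethyl group on the sulfonyl sulfur would fall. A 4-nitrobenzyl group would show whether the nitro group or the chain carries the gap.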